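The compounds below may be only part of what the source reports. "The series", "measured", "known", "first", "only" and "open" are said of these compounds alone.

Measured so far in an assay on HEK293 cells for positive allosteric modulation of metabotropic glutamate receptor 5 (Homo sapiens), read by FLIPR, with a stated time of 1 h; a lower number here means that less compound is needed, a higher number that more compound is needed for the effect:
compound 1 `O=C(C1CC12CCC2)N1CCc2nc(C#Cc3ccccc3)sc2C1` gives 3.9 nM
compound 2 `O=C(C1CCCCO1)N1CCc2nc(C#Cc3ccccc3)sc2C1` gives 320 nM

Within the data shown here, compound 2 holds the higher of the two numbers; its only measured neighbour is compound 1, and the sole step in the set, an 82-fold higher number from compound 1 to compound 2 (1.91 log units; beyond the scatter), separates them. Both differ only in the group attached to the carbonyl carbon of the shared core.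

Compound 3 `Cc1nc(C(=O)N2CCc3nc(C#Cc4ccccc4)sc3C2)cs1` is not yet measured. It differs from compound 2 at the same position: 2-methyl-1,3-thiazol-4-yl in place of oxan-2-yl on a carbonyl carbon. Among the measured compounds shown here, the only step that bears on this change is an 82-fold higher number from compound 1 to compound 2 (1.91 log units; beyond the scatter), which shows that exchanging the group on the carbonyl carbon can move the number a long way. For the measured compounds named here, no measured compound carries an aromatic group at this position, so the direction rests on little. Compound 3 is expected to give about 50 nM, within 6 nM to 400 nM. This estimate amounts to an expected step of a 6.4-fold lower number from compound 2 to compound 3 (0.81 log units; beyond the scatter).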

Compound 3, half-maximal effective concentration: 220 nM
Beside the measured number, compound 3's estimate is 4.4-fold (0.64 log units) below it; the measured number falls inside the stated range.
By their numbers in this assay, from the lowest: compound 1; then compounds 3 and 2 (each within the scatter of the next).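

In this assay, moving from a non-aromatic to an aromatic ring on the carbonyl carbon makes no readable difference, with a 1.5-fold lower number from compound 2 to compound 3 (0.16 log units; within the scatter). The two groups share little beyond their heavy-atom count, yet a 56-fold higher number from compound 1 to compound 3 (1.75 log units; beyond the scatter) is of the same order as an 82-fold higher number from compound 1 to compound 2 (1.91 log units; beyond the scatter), so among these three compounds only the all-carbon group of compound 1 gives a low number. Nothing measured alongside these potencies accounts for this gap.

As far as these compounds go, it remains open whether the low number of compound 1 follows from the absence of hetero atoms or from its particular fused small rings, a question that a plain cyclohexyl or phenyl group on the carbonyl carbon would address. From the compounds shown here alone, the part played by the methyl on the thiazole also remains open.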